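Removing the chloro group from the cyclohexyl amide

This account rests on a few compounds, and the source may have more. Where it says the series, first, only, none or still open, it means among the compounds named here.

Measured compounds:
compound 1 `CC(C)(C)C#Cc1cc(N(C(=O)[C@H]2CC[C@H](C)CC2)[C@H]2CC[C@@H](Oc3ccc(=O)[nH]n3)CC2)c(C(=O)O)s1`: > 20000 nM
compound 2 `CC(C)N(c1cc(C#CC(C)(C)C)sc1C(=O)O)C(=O)[C@H]1CC[C@H](Cl)CC1`: > 20000 nM
compound 3 `CC(C)(C)C#Cc1cc(N(C(=O)[C@H]2CC[C@H](C)CC2)[C@H]2CC[C@H](Oc3ccc(=O)[nH]n3)CC2)c(C(=O)O)s1`: > 20000 nM

All three compounds were tested in an ADME assay on MT4 cells (Homo sapiens) for cytotoxicity, with a stated time of 5 days; a lower number here means that less compound is tolerated, a higher number that more compound is tolerated. For compound 1 the value > 20000 nM is a limit of the assay rather than a number. For compound 3 the value > 20000 nM is likewise a limit. The step that the two limits leave unreadable from compound 1 to compound 3 therefore cannot be read, because of the limit of > 20000 nM in this assay, at which 3 of the 3 values shown sit; the two compounds are related only by the fact that compounds 1 and 3 differ only in the configuration as drawn.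

Compound 2 stands at the same place: its value > 20000 nM is a limit, as are the two other values shown, so nothing separates it from compound 1 or compound 3.

Compound 4 `CC(C)N(C(=O)C1CCCCC1)c1cc(C#CC(C)(C)C)sc1C(=O)O` differs from compound 2 by hydrogen in place of chloro on a saturated ring carbon, that is, (4-chlorocyclohexyl)carbonyl becomes cyclohexylcarbonyl. Among the compounds with values here, no measured step concerns this change; the only step available is the configurational one from compound 1 to compound 3, whose size is not readable. With every value at the limit, no step beyond the scatter can be expected in this assay, and the step that the limit leaves unreadable from compound 2 to compound 4 is estimated to be nil. Compound 4 is thus expected to give about 25000 nM, within 12000 nM to 60000 nM, most likely reported again only as a limit.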

Compound 4, half-maximal cytotoxic concentration: > 20000 nM
Compound 4 gave a limit, no number; the forecaster's own chance of this, stated with the estimate: 85%; the middle value does not contradict the limit.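

No step can be read from compound 2 to compound 4, where hydrogen takes the place of chloro on the saturated ring carbon, because both results are limits and not numbers: the limit of > 20000 nM in this assay, at which 4 of the 4 values shown sit.

The compounds shown leave open whether chloro and hydrogen at this place differ at all in this assay, and at what concentration any of the four compounds would harm the cells.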